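The source may report more compounds than this note shows. Statements on the series, on what has been measured and on what is new or still open speak of the compounds shown alone.

Of the compounds shown here, two built on a shared core have been measured so far. In a functional assay on TK-10 cells (Homo sapiens) for cytotoxicity, read by sulforhodamine B assay, with a stated time of 48 h, tested at 1 uM (on this read-out lower numbers stand for a stronger effect and higher numbers for a weaker effect at the one concentration tested), compound 2 `COc1cc(-c2cc(/C=C/C(=O)c3ccc(Cl)c(Cl)c3)[nH]n2)cc(OC)c1OC` gives 93%, the higher of the two numbers recorded. Its nearest neighbour on this read-out is compound 1 `COc1ccc(-c2cc(/C=C/C(=O)c3ccc(N)cc3)[nH]n2)cc1`; in this assay compound 1 gives 81%, and the gap between the two lies beyond the usual scatter of repeated measurements. The two compounds differ in more than one place, so the numbers show only where each stands, not what any single change does.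

Compound 3 `COc1cc(-c2cc(/C=C/C(=O)c3ccc(F)c(F)c3)[nH]n2)cc(OC)c1OC` is the next compound to be measured. It differs from compound 2 in one place: 3,4-difluorophenyl in place of 3,4-dichlorophenyl on a carbonyl carbon. Going by the values given here, no measured pair isolates this change, so nothing in the numbers so far shows how it moves the read-out. The step of a number 1 percentage points higher from compound 2 to compound 3 (within the scatter) is therefore expected to be small, not beyond the scatter, in either direction. On that basis compound 3 is estimated to give 94% in this assay, with a range from 80% to 106%.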

Compound 3, a percentage reported as activity, at one concentration (the size of the read-out at that concentration, not a potency): 85%
Estimate against measurement, compound 3: 9 percentage points above, and the stated range covers the measured number.
By their numbers in this assay, from the lowest: compounds 1, 3 and 2 (each within the scatter of the next, the first and the last beyond it).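

In this assay, going by these compounds alone, the pair of compound 2 and compound 3 is the first to isolate a single change, and it gives a number 8 percentage points lower from compound 2 to compound 3 (within the scatter) with 3,4-difluorophenyl in place of 3,4-dichlorophenyl on a carbonyl carbon. With the rest of the structure held the same, this exchange of one dihalogenated phenyl for another therefore gives no difference that can be told apart from the scatter of repeated measurements, at the one concentration tested. Nothing available here bears on what lies behind this result.

Within the data shown here, whether this place tolerates change more widely stays open, since the pair covers only two closely related groups and says nothing about a phenyl carrying a nitrile, a trifluoromethyl or a carboxylic acid on a carbonyl carbon. On these data alone, the separate contribution of the 4-aminophenyl group in compound 1 is also unresolved, as compound 1 differs from compound 2 and compound 3 in more than one place, and it remains unknown whether this exchange would look the same at other concentrations.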